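A few compounds are considered here, and "the series" means these few. Any claim that something is new, unique, unknown or untested is made for them only; others in the source may bear on it.

In an ADME assay on Vero cells (Chlorocebus sabaeus) for cytotoxicity, read by MTT assay, with a stated time of 72 h (a lower number here means that less compound is tolerated, a higher number that more compound is tolerated), compound 1 `Fc1ccc([C@@H]2C[C@@H]3Cc4ccc5ccccc5c4N2O3)cc1` gives only a limit, > 300000 nM. Compound 2 `Brc1ccc([C@@H]2C[C@@H]3Cc4ccc5ccccc5c4N2O3)cc1` also reaches only a limit in this assay, > 250000 nM. Compound 3 `Brc1cccc([C@@H]2C[C@@H]3Cc4ccc5ccccc5c4N2O3)c1` likewise gives a limit, > 250000 nM. The steps between them, a step that the two limits leave unreadable from compound 1 to compound 2, a step that the two limits leave unreadable from compound 1 to compound 3 and a step that the two limits leave unreadable from compound 2 to compound 3, cannot be sized, since every value sits at the limit of > 250000 nM in this assay, at which 2 of the 3 values shown sit, or (the limit of > 300000 nM in this assay, at which 1 of the 3 values shown sits). Compound 4 `Clc1ccccc1[C@@H]1C[C@@H]2Cc3ccc4ccccc4c3N1O2` has not been measured; it differs from compound 1 by 2-chlorophenyl in place of 4-fluorophenyl on a saturated ring carbon. The measured exchanges of one halogenated phenyl group for another all left the values at the limits, so no step beyond the scatter is expected in this assay, and compound 4 is expected most likely to give a limit again. The estimated step of a number no higher from compound 1 to compound 4 (the limit leaves the size open) is expected to be small. For compound 4 the expected value is 300000 nM, within 100000 nM to 1000000 nM.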

Compound 4, half-maximal cytotoxic concentration: 37200 nM
Beside the measured number, compound 4's estimate is 8.1-fold (0.91 log units) above it; measured number below the stated range.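

Unlike the exchanges among compound 1, compound 2 and compound 3, this change gives a readable number in this assay, and 2-chlorophenyl on this saturated ring carbon brings it down: an at least 8.0-fold lower number from compound 1 to compound 4 (0.90 log units; beyond the scatter), an at least 6.7-fold lower number from compound 3 to compound 4 (0.82 log units; beyond the scatter) and an at least 6.7-fold lower number from compound 2 to compound 4 (0.82 log units; beyond the scatter). Each step is only a minimum, because the starting values are limits: the limit of > 250000 nM in this assay, at which 2 of the 4 values shown sit. Compound 1 likewise starts from a limit: the limit of > 300000 nM in this assay, at which 1 of the 4 values shown sits.

From the compounds shown here alone, whether the chlorine or its place on the phenyl ring matters stays open; a 4-chlorophenyl or 2-bromophenyl group would separate the two. Going by these compounds, how a phenyl group carrying an amine or a carboxylic acid would behave at this carbon also stays open.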